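Swapping 2,4-dichlorophenyl for 3,4-dichlorophenyl

A few compounds are considered here, and "the series" means these few. Any claim that something is new, unique, unknown or untested is made for them only; others in the source may bear on it.

In a functional assay on HL-60 cells (Homo sapiens) for antiproliferative activity, with a stated time of 72 h (a higher number here means a weaker inhibitor, a lower number a stronger inhibitor), compound 1 `OC[C@H]1O[C@@H](n2cnc3c(NCc4ccccc4F)ncnc32)[C@H](O)[C@@H]1O` gives 3200 nM, compound 2 `OC[C@H]1O[C@@H](n2cnc3c(NCc4cccc(Br)c4)ncnc32)[C@H](O)[C@@H]1O` gives 8000 nM, and compound 3 `OC[C@H]1O[C@@H](n2cnc3c(NCc4ccc(Cl)cc4Cl)ncnc32)[C@H](O)[C@@H]1O` gives 96300 nM, the highest number of the three. Compound 4 `OC[C@H]1O[C@@H](n2cnc3c(NCc4ccc(Cl)c(Cl)c4)ncnc32)[C@H](O)[C@@H]1O` keeps the same atoms as compound 3 but carries 3,4-dichlorophenyl in place of 2,4-dichlorophenyl on a saturated chain carbon bound to a nitrogen on an aromatic ring. Among the measured compounds shown here, three steps bear on this. The two into 2,4-dichlorophenyl are large, a 30-fold higher number from compound 1 to compound 3 (1.48 log units; beyond the scatter) and a 12-fold higher number from compound 2 to compound 3 (1.08 log units; beyond the scatter), whereas a 2.5-fold higher number from compound 1 to compound 2 (0.40 log units; beyond the scatter) is modest. For the measured compounds named here, no measured compound carries 3,4-dichlorophenyl, and the closest reference is the 3-bromophenyl of compound 2 at 8000 nM. A large step to a lower number is therefore expected, estimated as a 6.0-fold lower number from compound 3 to compound 4 (0.78 log units; beyond the scatter). Compound 4 is estimated at 16000 nM, within an expected range of 5000 nM to 60000 nM.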

Compound 4, half-maximal inhibitory concentration: 2000 nM
Estimate against measurement, compound 4: 8.0-fold (0.90 log units) above; the whole stated range lies above it.
By their numbers in this assay, from the lowest: compounds 4 and 1 (each within the scatter of the next); then compound 2; then compound 3.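

With the same atoms, the 3,4-dichlorophenyl arrangement gives a 48-fold lower number from compound 3 to compound 4 (1.68 log units; beyond the scatter), so two chlorines on this ring are not poorly tolerated as such; the weak result belongs to 2,4-dichlorophenyl alone. Against single-halogen rings, 3,4-dichlorophenyl gives a 4.0-fold lower number from compound 2 to compound 4 (0.60 log units; beyond the scatter) from 3-bromophenyl, while a 1.6-fold lower number from compound 1 to compound 4 (0.20 log units; within the scatter) leaves it level with 2-fluorophenyl. No measured evidence accounts for the gap between the two dichlorophenyl arrangements.

Open, on these data alone, is how an unsubstituted phenyl or a methoxyphenyl would compare here. Also open, as far as these compounds go, is what a longer chain to the ring would do.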